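Trifluoromethyl for fluoro on a phenylsulfonyl compound

The compounds below may be only part of what the source reports. "The series", "measured", "known", "first", "only" and "open" are said of these compounds alone.

In a functional assay on SMMC-7721 cells (Homo sapiens) for cytotoxicity, read by MTT assay, with a stated time of 24 h (a lower number here means a stronger inhibitor, a higher number a weaker inhibitor), compound 1 `CN1C/C(=C\c2cccnc2)C(=O)/C(=C/c2ccccc2F)C1` gives 5420 nM, compound 2 `O=C1/C(=C/c2cccnc2)CN(S(=O)(=O)c2ccccc2)C/C1=C\c1ccccc1F` gives 19100 nM and compound 3 `CC(=O)Nc1ccc(S(=O)(=O)N2C/C(=C\c3cccnc3)C(=O)/C(=C/c3ccccc3F)C2)cc1` gives 10900 nM. Compound 2 thus sits at the upper end of these numbers, together with compound 3. Phenylsulfonyl in place of methyl on an amine nitrogen in a ring gave a 3.5-fold higher number from compound 1 to compound 2 (0.55 log units; beyond the scatter), while acetamido in place of hydrogen gave a 1.8-fold lower number from compound 2 to compound 3 (0.24 log units; within the scatter). Compound 4 `O=C1/C(=C/c2cccnc2)CN(S(=O)(=O)c2ccccc2)C/C1=C\c1ccccc1C(F)(F)F` instead carries trifluoromethyl in place of fluoro on an aromatic carbon. Neither measured step touches that group, so the data offer no direct guide and no shift beyond the scatter is expected. The estimated change is a 1.4-fold lower number from compound 2 to compound 4 (0.13 log units; within the scatter). Compound 4 is expected at 14000 nM, within an estimated range of 5500 nM to 36000 nM.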

Compound 4, half-maximal inhibitory concentration: 10900 nM
The estimate for compound 4 lay 1.3-fold (0.11 log units) above the measured number; low and high end bracket the measured number.
By their numbers in this assay, from the lowest: compounds 1, 3, 4 and 2 (each within the scatter of the next, the first and the last beyond it).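

This is the first change shown at this position. In this assay, going from 2-fluorophenyl to 2-(trifluoromethyl)phenyl gave a 1.8-fold lower number from compound 2 to compound 4 (0.24 log units; within the scatter) and so shows that, on the phenylsulfonyl compound, trifluoromethyl with its 4 heavy atoms can replace fluoro with no shift beyond the scatter. Nothing available explains this result. Still open, on these data alone, is how an amine or a carboxylic acid would read on this aromatic carbon, and whether the same change would read alike with methyl in place of phenylsulfonyl, as in compound 1.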